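Halogen swap on the fused benzenoid ring of the series

The source may report more compounds than this note shows. Statements on the series, on what has been measured and on what is new or still open speak of the compounds shown alone.

Three compounds of the shared core carry a substituent on the fused benzenoid ring and have been tested in a functional assay on HEp-2 cells (Homo sapiens) for inhibition, read by sulforhodamine B assay, with a stated time of 48 h; on this read-out lower numbers stand for stronger inhibition and higher numbers for weaker inhibition. Compound 1 `Cc1ccc2occ(C3N=C(c4ccccc4)SS3)c(=O)c2c1` reaches only the limit of the assay, > 100000 nM, and this is a limit rather than a number. Compound 2 `O=c1c(C2N=C(c3ccccc3)SS2)coc2ccc(Cl)cc12` gives 74900 nM in this assay, and compound 3 `O=c1c(C2N=C(c3ccccc3)SS2)coc2cc(Cl)c(Cl)cc12` gives 98000 nM. Compound 2 therefore holds the lowest of the two numbers shown, with compound 3 within the scatter of it, and the third value is a limit (the limit of > 100000 nM in this assay, at which 1 of the 3 values shown sits). The measured steps are small: an at least 1.3-fold lower number from compound 1 to compound 2 (0.12 log units; that floor lies within the scatter) and a 1.3-fold higher number from compound 2 to compound 3 (0.12 log units; within the scatter), neither of which separates from the scatter.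

Compound 4 `O=c1c(C2N=C(c3ccccc3)SS2)coc2ccc(F)cc12` differs from compound 2 by the change (fluoro in place of chloro on an aromatic carbon). For the measured compounds named here, no measured step exchanges one halogen for another, and the two steps that do touch this ring stay within the scatter, so no step beyond the scatter is expected here either. The step from compound 2 to compound 4 is estimated as a 1.2-fold higher number from compound 2 to compound 4 (0.08 log units; within the scatter). Compound 4 is thus expected to give about 90000 nM in this assay, within a range of 40000 nM to 200000 nM.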

Compound 4, half-maximal inhibitory concentration: 98600 nM
The estimate for compound 4 lay 1.1-fold (0.04 log units) below the measured number; the measured number falls inside the stated range.
By their numbers in this assay, from the lowest: compounds 2, 3 and 4 (each within the scatter of the next). At a limit, above all of these: compound 1.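

In this assay, the exchange of one halogen for another at this position gives a 1.3-fold higher number from compound 2 to compound 4 (0.12 log units; within the scatter), so chloro and fluoro are not told apart here. Replacing methyl with fluoro at the same position gives an at least 1.0-fold lower number from compound 1 to compound 4 (0.00 log units; that floor lies within the scatter), and that floor does not separate these two groups either. Compound 1 stays a limit of the assay and not a number: the limit of > 100000 nM in this assay, at which 1 of the 4 values shown sits.

Going by these compounds, whether an amine, a carboxylic acid or a methoxy group at this position would give a step beyond the scatter remains open. On these data alone, with every step on this ring so far inside the scatter, it is also open whether this position can move the number in this assay at all.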